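The compounds below may be only part of what the source reports. "The series", "measured", "known", "first", "only" and "open" are said of these compounds alone.

Three compounds share one core and differ only in a side group on a saturated chain carbon, two bonds along the chain from an amide-type nitrogen and a carbonyl carbon. Compound 1 `COC(=O)N[C@@H](CSC)C(=O)N1CCC[C@H]1c1ncc(-c2ccc(-c3ccc(-c4cnc([C@@H]5CCCN5C(=O)[C@@H](NC(=O)OC)C(C)C)[nH]4)cc3)cc2)[nH]1` carries a methylsulfanyl there; compound 2 `COC(=O)N[C@@H](CSC(C)(C)C)C(=O)N1CCC[C@H]1c1ncc(-c2ccc(-c3ccc(-c4cnc([C@@H]5CCCN5C(=O)[C@@H](NC(=O)OC)C(C)C)[nH]4)cc3)cc2)[nH]1` carries a (tert-butyl)sulfanyl; compound 3 `COC(=O)N[C@@H](CCSC)C(=O)N1CCC[C@H]1c1ncc(-c2ccc(-c3ccc(-c4cnc([C@@H]5CCCN5C(=O)[C@@H](NC(=O)OC)C(C)C)[nH]4)cc3)cc2)[nH]1` carries a (methylsulfanyl)methyl. In an ADME assay on CCRF-CEM cells (Homo sapiens) for cytotoxicity (a higher number here means that more compound is tolerated, a lower number that less compound is tolerated), compound 1 gives 11000 nM, compound 2 gives 10000 nM and compound 3 gives 11000 nM. Compound 3 thus stands level with compound 1 at the digits shown, the two together the highest of the three numbers, and its step from compound 2 is a 1.1-fold higher number from compound 2 to compound 3 (0.04 log units; within the scatter). The other steps are of the same kind: a 1.1-fold lower number from compound 1 to compound 2 (0.04 log units; within the scatter) and no change at the digits printed from compound 1 to compound 3 (within the scatter). Going by the values given here, every change tried at this position so far has left the read-out where it was.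

Compound 4 `COC(=O)N[C@@H](C[S+]([O-])Cc1ccccc1)C(=O)N1CCC[C@H]1c1ncc(-c2ccc(-c3ccc(-c4cnc([C@@H]5CCCN5C(=O)[C@@H](NC(=O)OC)C(C)C)[nH]4)cc3)cc2)[nH]1` changes the same position again, this time more heavily: a group of 9 heavy atoms (7 carbon, 1 oxygen, 1 sulfur; one six-membered aromatic ring of carbon only) in place of a group of 3 heavy atoms (2 carbon, 1 sulfur; no ring), on a saturated chain carbon, two bonds along the chain from an amide-type nitrogen and a carbonyl carbon. The three measured steps all bear on it, since they alter the same spot, and all three lie within the scatter. The expected step from compound 3 is therefore a 1.1-fold lower number from compound 3 to compound 4 (0.04 log units; within the scatter), that is, no change beyond the scatter in either direction. For compound 4 the expected value in this assay is 10000 nM, with a range from 4000 nM to 25000 nM.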

Compound 4, half-maximal cytotoxic concentration: 11000 nM
Beside the measured number, compound 4's estimate is 1.1-fold (0.04 log units) below it; the range from low to high includes it.
By their numbers in this assay, from the lowest: compounds 2, 1, 3 and 4 (each within the scatter of the next).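

The three earlier groups at this saturated chain carbon have no ring, so they could not show whether the position also accepts a ring-bearing group. Compound 4 addresses that: a group of 9 heavy atoms, with one six-membered aromatic ring of carbon only, leaves the read-out in this assay unmoved against each earlier side group (no change at the digits printed from compound 3 to compound 4 (within the scatter); no change at the digits printed from compound 1 to compound 4 (within the scatter); a 1.1-fold higher number from compound 2 to compound 4 (0.04 log units; within the scatter)). Across these four compounds, then, neither the number of heavy atoms in the group nor the presence of this ring separates them in this cell test, although nothing available explains why the read-out stays level.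

Going by these compounds, it remains open whether the same holds for groups of another kind at this position, such as an amine, a carboxylic acid or a longer chain. A flat read-out in this assay also says nothing about how these side groups behave in any other test, so the position may still matter for measures beyond the tolerance of these cells.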